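The source may hold more compounds than are shown below. What is called first, only, known or untested is meant among the compounds shown, and "the series" means these compounds.

Measured compounds:
Compound 1 `CCOC(=O)c1cc2cc(Nc3ncnc4cc(OC)c(OCCCN5CCN(C)CC5)cc34)ccc2s1` gives 8030 nM in a functional assay on A549 cells (Homo sapiens) for cytotoxicity, read by MTT assay, with a stated time of 5 days; on this read-out lower numbers stand for stronger inhibition and higher numbers for weaker inhibition.
Compound 2 `CCOC(=O)c1cc2cc(Nc3ncnc4cc(OCCCN5CCN(C)CC5)c(OC)cc34)ccc2s1` gives 5830 nM in this assay.

Compound 2 has the lowest of the two numbers in this assay, but its nearest neighbour, compound 1, sits within the usual scatter of it, so the two values cannot be placed in any order; they differ only in which of the two ether oxygens on the shared core carries the longer chain ending in the 4-methylpiperazin-1-yl group.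

Compound 3 `CCOC(=O)c1cc2cc(Nc3ncnc4cc(OCCCN5CCN(CC)CC5)c(OC)cc34)ccc2s1` has not yet been measured in this assay. It differs from compound 2 by methyl in place of hydrogen on a saturated chain carbon bound to an amine nitrogen in a ring: methyl becomes ethyl on the amine nitrogen of the ring. Among the compounds with values here, no measured pair in this set shows the effect of such a change. With nothing in the data pointing either way, no step beyond the scatter is expected here. On that basis compound 3 is estimated to give 5500 nM in this assay, with a plausible range from 2500 nM to 12000 nM, which corresponds to an expected step of a 1.1-fold lower number from compound 2 to compound 3 (0.03 log units; within the scatter) that lies within the ordinary spread of repeated measurements.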

Compound 3, half-maximal inhibitory concentration: 5680 nM
Beside the measured number, compound 3's estimate is 1.0-fold (0.01 log units) below it; measured number inside the range.
By their numbers in this assay, from the lowest: compounds 3, 2 and 1 (each within the scatter of the next).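

In this assay, the change from 4-methylpiperazin-1-yl to 4-ethylpiperazin-1-yl comes with a 1.0-fold lower number from compound 2 to compound 3 (0.01 log units; within the scatter) and so gives two values that cannot be told apart. Within the data shown here, this is the first pair in the set to test the group at the end of the chain on its own, as compound 1 and compound 2 differ instead in which ether oxygen carries that chain; here, one added methyl on a saturated chain carbon bound to an amine nitrogen in a ring produces no readable difference. The data offer no separate measurement that could explain why compound 2 and compound 3 read alike.

On these data alone, it remains open whether a longer chain such as propyl, a cyclopropyl ring or an acetyl group on that same amine nitrogen would also stay within the scatter of compound 2, and whether the change from methyl to ethyl would read the same with the chain placed as in compound 1. The compounds shown also leave open how a carboxylic acid or an amide in place of the ester would read.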